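The source may hold more compounds than are shown below. What is called first, only, known or untested is meant among the compounds shown, and "the series" means these compounds.

The series shares one core, seen in compound 1 `CC(CSc1nnc(-c2ccncc2)s1)C(=O)NCc1ccc(Cl)cc1` and compound 2 `CC(CSc1nnc(-c2ccncc2)s1)C(=O)Nc1ccccc1`. In an ADME assay on HepG2 cells (Homo sapiens) for cytotoxicity, with a stated time of 3 days (a lower number here means that less compound is tolerated, a higher number that more compound is tolerated), compound 1 is recorded as "not determined" (no result reported), so no number stands against it. In this assay compound 2 gives > 50000 nM, which is a limit of the assay and not a number. Among the measured compounds shown here, compound 2 therefore sits at the limit of > 50000 nM in this assay, at which 1 of the 2 values shown sits, and the only other entry carries no number at all; no step between measured compounds can be drawn from these two.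

The next compound is compound 3 `CC(CSc1nnc(-c2ccncc2)s1)C(=O)Nc1ccccc1Cl`. It differs from compound 2 as follows: chloro in place of hydrogen on an aromatic carbon. The change is a single chloro on an aromatic carbon of the six-membered aromatic ring of carbon only, ortho to a large group.

For the measured compounds named here, with only a limit for compound 2, no size of step is known in this assay; for a change of one heavy atom the expectation is no step beyond the scatter, with compound 3 staying at or near the limit. On this basis compound 3 is estimated at 50000 nM, within 20000 nM to 100000 nM. The expected step is a number no higher from compound 2 to compound 3 (the limit leaves the size open), i.e. none beyond the scatter.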

Compound 3, half-maximal cytotoxic concentration: > 50000 nM
Compound 3: a limit, no number (the forecaster's own chance of this, stated with the estimate: 70%); the middle value sits exactly at the limit.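

In this assay compound 3 gives > 50000 nM, a limit of the assay and not a number. Compound 2 stands at a limit as well, so no step can be read between compound 2 and compound 3. The compounds shown leave open whether any change on the shared core gives a measurable value: the limit of > 50000 nM in this assay, at which 2 of the 3 values shown sit.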